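A few compounds are considered here, and "the series" means these few. Any claim that something is new, unique, unknown or untested is made for them only; others in the source may bear on it.

Measured compounds:
Compound 1 `Cn1nnnc1SCC(=O)N/N=c1/scc(-c2ccccc2)n1-c1ccccc1` gives 173 ug/mL in an ADME assay on NIH3T3 cells (Mus musculus) for cytotoxicity, read by MTT assay, with a stated time of 24 h; on this read-out lower numbers stand for stronger inhibition and higher numbers for weaker inhibition.
Compound 2 `Cc1nnc(SCC(=O)N/N=c2/scc(-c3ccc([N+](=O)[O-])cc3)n2-c2ccccc2)s1` gives 177 ug/mL in this assay.

Compound 2 has the highest of the two numbers, but the number for compound 1 is within the scatter of it, so the two compounds cannot be told apart on this read-out. Compound 3 `Cn1nnnc1SCC(=O)N/N=c1/scc(-c2ccc([N+](=O)[O-])cc2)n1-c1ccccc1` has not yet been measured. It differs from compound 2 at one place, (1-methyl-1H-tetrazol-5-yl in place of 5-methyl-1,3,4-thiadiazol-2-yl on a sulfur). Among the measured compounds shown here, the same ring swap is the one part that separates compound 1 from compound 2, and those two compounds sit at indistinguishable numbers, though they also differ elsewhere, so no clean step is available. With nothing in the measured numbers pointing either way, the step from compound 2 to compound 3 is expected to be a 1.0-fold lower number from compound 2 to compound 3 (0.00 log units; within the scatter), that is none beyond the scatter. Compound 3 is therefore estimated at 175 ug/mL, with a range from 100 ug/mL to 300 ug/mL.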

Compound 3, half-maximal inhibitory concentration: 167 ug/mL
Compound 3: the middle estimate sits 1.0-fold (0.02 log units) above what was measured; measured number inside the range.
By their numbers in this assay, from the lowest: compounds 3, 1 and 2 (each within the scatter of the next).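

Taken alone for the first time, 1-methyl-1H-tetrazol-5-yl in place of 5-methyl-1,3,4-thiadiazol-2-yl on a sulfur gives a 1.1-fold lower number from compound 2 to compound 3 (0.03 log units; within the scatter) in this assay, so this read-out does not separate the two rings. Nitro in place of hydrogen on an aromatic carbon can now also be read alone and gives a 1.0-fold lower number from compound 1 to compound 3 (0.02 log units; within the scatter) on the same read-out, so neither change shown here can be told from repeat-measurement noise. Nothing measured here explains these results.

From the compounds shown here alone, it remains open whether a different kind of group on the sulfur, such as an amine or a carboxylic acid, or a methoxy or chloro group in place of nitro, would move the number beyond the scatter. Among the compounds shown here, the ring swap is also seen only with nitro present, and nitro only with 1-methyl-1H-tetrazol-5-yl, so either step could differ in another setting.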